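The source may hold more compounds than are shown below. What is called first, only, known or untested is meant among the compounds shown, and "the series" means these compounds.

In a functional assay on MCF7 cells (Homo sapiens) for inhibition (a lower number here means a stronger inhibitor, a higher number a weaker inhibitor), compound 1 `CCn1c(=O)/c(=C2\Sc3ccccc3N2C)s/c1=C\c1ccncc1Nc1ccccc1F` gives 330 nM and compound 2 `CCn1c(=O)/c(=C2\Sc3cc(F)ccc3N2C)s/c1=C\c1ccncc1Nc1ccccc1F` gives 230 nM. These two cannot be told apart, with a 1.4-fold lower number from compound 1 to compound 2 (0.16 log units; within the scatter). Compound 3 `CCc1ccc2c(c1)S/C(=c1/s/c(=C\c3ccncc3Nc3ccccc3F)n(CC)c1=O)N2C` stands apart at 1200 nM, with a 3.6-fold higher number from compound 1 to compound 3 (0.56 log units; beyond the scatter) and a 5.2-fold higher number from compound 2 to compound 3 (0.72 log units; beyond the scatter).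

The next compound is compound 4 `CCn1c(=O)/c(=C2\Sc3cc(F)ccc3N2C)s/c1=C\c1ccncc1Nc1ccccc1Cl`. It differs from compound 2 by chloro in place of fluoro on an aromatic carbon, ortho to a large group, which turns 2-fluorophenyl to 2-chlorophenyl: chloro in place of fluoro on an aromatic carbon.

Among the compounds with values here, no measured step touches this group, so the evidence is indirect. The measured single-group swaps lie elsewhere on the shared core, and they run from within the scatter, as in a 1.4-fold lower number from compound 1 to compound 2 (0.16 log units; within the scatter), to modest, as in a 5.2-fold higher number from compound 2 to compound 3 (0.72 log units; beyond the scatter). On that basis, exchanging one halogen for another is expected to give no change beyond the scatter in this assay, with no direction favoured.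

The estimated step, a 1.1-fold higher number from compound 2 to compound 4 (0.04 log units; within the scatter), is expected to stay within the scatter. For compound 4 the estimated value is 250 nM, with an expected range of 100 nM to 650 nM.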

Compound 4, half-maximal inhibitory concentration: 1300 nM
For compound 4 the middle estimate is 5.2-fold (0.72 log units) below the measured one; measured number outside the range, above it.
By their numbers in this assay, from the lowest: compounds 2 and 1 (each within the scatter of the next); then compounds 3 and 4 (each within the scatter of the next).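

Until now, the steps lay elsewhere on the shared core. In this assay, the change from 2-fluorophenyl to 2-chlorophenyl gives a 5.7-fold higher number from compound 2 to compound 4 (0.75 log units; beyond the scatter), so this position, ortho to a large group, responds beyond the scatter to the exchange of one halogen for another, though one heavy atom leaves and one enters. Nothing shown here bears on the reason for this rise.

Only fluoro and chloro are shown at this position, so it remains open how a methoxy group, a nitrile or a plain hydrogen there would read, and whether any of them would match the fluoro compound. The chloro group is also shown only with the fluoro-bearing core of compound 4, so its step on the core of compound 1 remains open.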